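The source may report more compounds than this note shows. Statements on the series, on what has been measured and on what is new or still open speak of the compounds shown alone.

Two boronic acids share a core and differ in one group on it. Compound 1 `CC(C)C[C@H](NC(=O)[C@@H](N)C(C)(C)C)B(O)O` carries a tert-butyl, and in an ADME assay on FSCLL cells (Homo sapiens) for cytotoxicity, read by MTT assay, with a stated time of 24 h (a higher number here means that more compound is tolerated, a lower number that less compound is tolerated), compound 1 gives 710 nM. Compound 2 `CC(C)C[C@H](NC(=O)[C@@H](N)CO)B(O)O` carries a hydroxymethyl, and in this assay compound 2 gives 1700 nM, the higher of the two numbers; the change is a 2.4-fold higher number from compound 1 to compound 2 (0.38 log units; beyond the scatter). Compound 3 `CC(C)C[C@H](NC(=O)[C@H](C)N)B(O)O` is the next member: hydrogen in place of hydroxy on a saturated chain carbon, two bonds along the chain from an amine nitrogen and a carbonyl carbon. Among the measured compounds shown here, no measured step removes a hydroxy alone, so only the step from compound 1 to compound 2 bears on this, and it does so loosely: it exchanged tert-butyl for hydroxymethyl rather than trimming a hydroxy. With compound 2 holding the highest number and compound 1 near it, a modest move in either direction would fit, and compound 3 is expected to land between them, a step of a 1.4-fold lower number from compound 2 to compound 3 (0.15 log units; within the scatter). The estimate for compound 3 in this assay is 1200 nM, with a range from 500 nM to 3500 nM.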

Compound 3, half-maximal cytotoxic concentration: 3200 nM
Compound 3: middle estimate off by 2.7-fold (0.43 log units), on the low side; measured number inside the range.
By their numbers in this assay, from the lowest: compound 1; then compounds 2 and 3 (each within the scatter of the next).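

Hydrogen in place of hydroxy at this position amounts to a 1.9-fold higher number from compound 2 to compound 3 (0.27 log units; within the scatter) in this assay, so compound 2 and compound 3 cannot be told apart here, and the hydroxy shows no readable effect of its own. Methyl in place of tert-butyl on the same carbon gives a 4.5-fold higher number from compound 1 to compound 3 (0.65 log units; beyond the scatter) and is a clearer separation, so among these three compounds only the tert-butyl of compound 1 stands apart, with compound 2 and compound 3 together on the more tolerated side. Nothing available explains these numbers.

From the compounds shown here alone, whether an ethyl, an isopropyl, an aminomethyl or a carboxylic acid on this carbon would fall with compound 1 or with compound 3 remains open. So does whether these exchanges would give similar steps on another core.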